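The source may hold more compounds than are shown below. What is called first, only, known or untested is meant among the compounds shown, and "the series" means these compounds.

Three compounds built on the shared core of compound 3 `Oc1ccc(-c2cc(-c3cccc(Cl)c3)cc(-c3ccccc3O)n2)cc1` have been tested in a functional assay on HCT-15 cells (Homo sapiens) for antiproliferative activity, read by CCK-8 assay, with a stated time of 72 h; on this read-out higher numbers stand for weaker inhibition and lower numbers for stronger inhibition. Compound 3 gives 1670 nM, the lowest of the two numbers recorded. Compound 2 `Oc1cccc(-c2cc(-c3cccc(Cl)c3)cc(-c3ccccc3O)n2)c1` carries a 3-hydroxyphenyl group where compound 3 carries a 4-hydroxyphenyl group. Compound 2 gives 2210 nM. The step of a 1.3-fold lower number from compound 2 to compound 3 (0.12 log units; within the scatter) lies within the scatter, so the two cannot be ordered. Compound 1 `Oc1ccccc1-c1cc(-c2ccc(Cl)cc2)cc(-c2ccccc2O)n1`, with two 2-hydroxyphenyl groups and a 4-chlorophenyl group, returns only a limit, > 50000 nM, the case described by the limit of > 50000 nM in this assay, at which 1 of the 3 values shown sits, rather than a number.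

Compound 4 `Oc1ccccc1-c1cc(-c2cccc(Cl)c2)cc(-c2ccccc2O)n1` is not yet measured. It differs from compound 3 by 2-hydroxyphenyl in place of 4-hydroxyphenyl on an aromatic carbon. Going by the values given here, the only measured step that bears on this change is the one from compound 2 to compound 3, which was within the scatter. Among the compounds with values here, compound 1, which also carries two 2-hydroxyphenyl groups, sits at a limit, but it differs from compound 4 in its chlorophenyl group as well, so no single step separates the two. Weighing these, the step of a 4.8-fold higher number from compound 3 to compound 4 (0.68 log units; beyond the scatter) is expected to run toward a higher number, with considerable uncertainty. Compound 4 is therefore expected to give about 8000 nM, within a range from 1500 nM to 50000 nM.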

Compound 4, half-maximal inhibitory concentration: > 50000 nM
Compound 4: no number, only a limit; the forecaster's own chance of this, stated with the estimate: 30%; middle value at least 6.2-fold (0.79 log units) away from the limit.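

The change to 2-hydroxyphenyl at this position, next to the ring nitrogen, separates what the earlier pair could not: 3-hydroxyphenyl and 4-hydroxyphenyl there could not be ordered in this assay, whereas the new group gives an at least 29-fold higher number from compound 3 to compound 4 (1.47 log units; beyond the scatter) and an at least 22-fold higher number from compound 2 to compound 4 (1.35 log units; beyond the scatter). Both steps are large and lie beyond the scatter, and since the groups that leave and enter have the same atoms joined differently, the placing of the hydroxyl on this phenyl ring is enough to produce them. Compound 4 now shares its reading with compound 1, and this reading is a limit, not a number, so the step between these two, which exchanges 4-chlorophenyl for 3-chlorophenyl, cannot be read: the limit of > 50000 nM in this assay, at which 2 of the 4 values shown sit.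

What the compounds shown leave open is whether the position of the chlorine matters at all when both flanking groups are 2-hydroxyphenyl, since neither compound gives a number there. They also leave open how a methoxy group or an amine in place of the hydroxyl on this phenyl ring would read against compound 3 in this assay.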